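Swapping the aryl substituent in a nitroimidazooxazine series

The source may hold more compounds than are shown below. What is called first, only, known or untested is meant among the compounds shown, and "the series" means these compounds.

Two compounds built on a shared nitroimidazooxazine core, compound 1 `C[C@]1(CN2CCc3nc(-c4cccc(F)c4)ccc3C2)Cn2cc([N+](=O)[O-])nc2O1` and compound 2 `C[C@]1(CN2CCc3nc(-c4ccc(C#N)cc4)ccc3C2)Cn2cc([N+](=O)[O-])nc2O1`, have been tested in an ADME assay on Vero cells (Chlorocebus sabaeus) for cytotoxicity, read by MTT assay, with a stated time of 72 h; on this read-out higher numbers stand for lower toxicity in this test and lower numbers for higher toxicity in this test. For compound 1 the result is a limit rather than a number, > 32 ug/mL, marking the top of the tested range (the limit of > 32 ug/mL in this assay, at which 1 of the 2 values shown sits). Compound 2 carries a 4-cyanophenyl group in place of the fluorophenyl of compound 1, and for compound 2 the entry in this assay reads "not determined" (no result reported), so no number can be given for where it stands. Compound 3 `C[C@]1(CN2CCc3nc(-c4ccc(Cl)cc4F)ccc3C2)Cn2cc([N+](=O)[O-])nc2O1` is the next member, differing from compound 2 only by 4-chloro-2-fluorophenyl in place of 4-cyanophenyl on an aromatic carbon. Going by the values given here, with no measured step between any two compounds of this set, the size and direction of the change from compound 2 to compound 3 in this assay cannot be read from the data. Compound 3 is expected to show a cytotoxic concentration around 40 ug/mL, most likely reported between 20 ug/mL and 100 ug/mL.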

Compound 3, half-maximal cytotoxic concentration: > 32 ug/mL
Compound 3 ended at the assay's limit; the forecaster's own chance of this, stated with the estimate: 75%; the middle value is on the limit's open side.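

The result for compound 3 in this assay is a limit, as is that of compound 1, so no step from compound 1 to compound 3 can be read: the limit of > 32 ug/mL in this assay, at which 2 of the 3 values shown sit. The compounds shown leave open how far past that limit the true values of compound 1 and compound 3 lie, and where compound 2 stands.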